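The compounds below may be only part of what the source reports. "The series", "measured", "known", "first", "only" and "open" are said of these compounds alone.

Of the compounds shown here, three have been read in a functional assay with Rattus norvegicus as the target; on this read-out higher numbers stand for an effect only at larger amounts of compound and lower numbers for an effect already at smaller amounts: compound 1 (`CC(C)(C)c1ccc(C/N=C(\S)NC(c2ccccc2)c2ccc(NS(C)(=O)=O)cc2)cc1`), compound 2 (`CC(C)C(/N=C(\S)NCc1ccc(C(C)(C)C)cc1)c1ccc(NS(C)(=O)=O)cc1`) and compound 3 (`C[C@@H](/N=C(\S)NCc1ccc(C(C)(C)C)cc1)c1ccc([N+](=O)[O-])cc1`). Compound 1 gives > 100000 nM, which is a limit of the assay and not a number. Compound 2 gives > 100000 nM, also a limit. Compound 3 gives > 100000 nM, again a limit and not a number. Compound 3 therefore has no number of its own and stands with the other two at the limit of > 100000 nM in this assay, at which 3 of the 3 values shown sit.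

Compound 4 (`C[C@@H](/N=C(\S)NCc1ccc(C(C)(C)C)cc1)c1ccc(C(C)(C)C)cc1`) has not yet been measured. It differs from compound 3 by a single change: tert-butyl in place of nitro on an aromatic carbon. The tert-butyl takes the place of the nitro on the aromatic carbon para to a large group, and the rest of the structure stays the same.

Among the compounds with values here, no two measured compounds differ in one place, so no measured step gives a size for this change. In this assay, the expectation is for no shift beyond the scatter and no firm direction. The estimated a number no higher from compound 3 to compound 4 (the limit leaves the size open) should be read with that caution. The expectation rests on compound 3 at > 100000 nM, which is a limit. For compound 4 the estimated value is 100000 nM, with an expected range of 30000 nM to 300000 nM.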

Compound 4, half-maximal effective concentration: > 100000 nM
Compound 4 ended at the assay's limit; the forecaster's own chance of this, stated with the estimate: 80%; the middle value sits exactly at the limit.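

Compound 3 and compound 4 both sit at a limit of the assay and not at a number, so no step can be read for tert-butyl in place of nitro. The compounds shown leave open whether any member of this series reaches a measurable value in this assay, and every reading stands at one limit: the limit of > 100000 nM in this assay, at which 4 of the 4 values shown sit.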